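The compounds below may be only part of what the source reports. "The series", "measured", "known", "first", "only" and "open" are said of these compounds alone.

Compound 1, `CN(C)CCC(OC(=O)Nc1ccc(-c2ccccc2)cc1)c1ccc(Cl)cc1`: 269 nM
Compound 2, `CN(C)CCC(OC(=O)Nc1ccc(Oc2ccccc2)cc1)c1ccc(Cl)cc1`: 191 nM
Compound 3, `CN(C)CCC(NC(=O)Nc1ccc(-c2ccccc2)cc1)c1ccc(Cl)cc1`: 145 nM

Of the compounds shown here, three have so far been tested in an assay on NIH3T3 cells with Urotensin-2 receptor (Homo sapiens) as the target; on this read-out higher numbers stand for an effect only at larger amounts of compound and lower numbers for an effect already at smaller amounts. Compound 1, with the structure `CN(C)CCC(OC(=O)Nc1ccc(-c2ccccc2)cc1)c1ccc(Cl)cc1`, gives 269 nM in this assay. Compound 2, `CN(C)CCC(OC(=O)Nc1ccc(Oc2ccccc2)cc1)c1ccc(Cl)cc1`, differs from compound 1 in a single place: phenoxy in place of phenyl on an aromatic carbon. That change produced a 1.4-fold lower number from compound 1 to compound 2 (0.15 log units; within the scatter). Compound 3, `CN(C)CCC(NC(=O)Nc1ccc(-c2ccccc2)cc1)c1ccc(Cl)cc1`, is built on a different core, and how its core differs from that of compound 1 is not broken down here. In this assay compound 3 gives 145 nM. The three measured values all lie within the usual scatter of one another, so none of the three compounds can be set apart from the others on this read-out.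

Compound 4, `CN(C)CCC(NC(=O)Nc1ccc(Oc2ccccc2)cc1)c1ccc(Cl)cc1`, has not yet been measured. It differs from compound 3 in one place only: phenoxy in place of phenyl on an aromatic carbon. Going by the values given here, this is the same change that led from compound 1 to compound 2, and the place is described in the same words, so the earlier step is the only guide available. Among the compounds with values here, since that step, a 1.4-fold lower number from compound 1 to compound 2 (0.15 log units; within the scatter), was small, and only one example of it exists, a step of similar size is the natural expectation. Compound 4 is therefore expected to show a 1.3-fold lower number from compound 3 to compound 4 (0.12 log units; within the scatter). For compound 4 the estimate in this assay is 110 nM, with a likely range from 50 nM to 250 nM.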

Compound 4, half-maximal effective concentration: 110 nM
The estimate for compound 4 equals the measured number at the digits printed, within the range that was stated.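

Putting phenoxy in place of phenyl on the core of compound 3 gives, in this assay, a 1.3-fold lower number from compound 3 to compound 4 (0.12 log units; within the scatter), a step small enough to be ordinary variation between repeated measurements. Set beside the same change on the core of compound 1, the new step agrees with the earlier one: the same change on two cores in this assay, a 1.4-fold lower number (0.15 log units; within the scatter) from compound 1 to compound 2 and a 1.3-fold lower number (0.12 log units; within the scatter) from compound 3 to compound 4, 1.1-fold (0.03 log units) apart, within the scatter of two such steps. This shows that, on these two cores, the swap behaves alike and neither core stands out, but both steps are too small to tell from no change at all, so it does not show that phenoxy is better than phenyl, and two cores are too few to establish a rule for the series.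

The compounds shown leave open what happens when the phenyl or phenoxy group gives way to a clearly different one, such as a benzyloxy group or a carboxylic acid, and whether such a change would carry from one core to the other. Also open, on these data alone, are whether the dimethylamino group can be exchanged for a primary amine or a longer chain, and whether the phenoxy-for-phenyl step stays this small on a third core.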